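Solubility notes on a dienone series with methoxyalkylamine chains

The source may hold more compounds than are shown below. What is called first, only, known or untested is meant among the compounds shown, and "the series" means these compounds.

Measured compounds:
- Compound 1, `COCCNC(=C\C(=O)/C=C/c1ccc(O)cc1)/C=C/c1ccc(O)cc1`: 46100 nM
- Compound 2, `COCCNC(=C\C(=O)/C=C/c1ccc(O)c(OC)c1)/C=C/c1ccc(O)c(OC)c1`: 12700 nM
- Compound 3, `COCCCNC(=C\C(=O)/C=C/c1ccc(O)cc1)/C=C/c1ccc(O)cc1`: 14900 nM

All three have been run in a physicochemical assay for solubility, using the shake flask method, in phosphate buffer, with a stated time of 24 h, at pH 6.8; on this read-out lower numbers stand for lower solubility and higher numbers for higher solubility. Compound 1 gives 46100 nM, compound 3 gives 14900 nM, and compound 2 gives 12700 nM. Compound 2 and compound 3 sit within the scatter of each other, so no order between them is claimed; compound 1 stands apart from both beyond the scatter.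

Compound 1 and compound 3 share a core and differ only by methoxymethyl in place of methoxy on a saturated chain carbon, two bonds along the chain from an amine nitrogen. That change gave a 3.1-fold lower number from compound 1 to compound 3 (0.49 log units; beyond the scatter) in this assay.

Compound 4, `COCCCNC(=C\C(=O)/C=C/c1ccc(O)c(OC)c1)/C=C/c1ccc(O)c(OC)c1`, is not yet measured. It differs from compound 2 by methoxymethyl in place of methoxy on a saturated chain carbon, two bonds along the chain from an amine nitrogen, the same change as from compound 1 to compound 3, at the same place. The difference between the core of compound 2 and the core of compound 1 is not broken down here.

Among the measured compounds shown here, for compound 4 the expectation is that the step from compound 2 repeats the earlier one in size, giving an estimated 2.8-fold lower number from compound 2 to compound 4 (0.45 log units; beyond the scatter), because the only comparable step is a 3.1-fold lower number from compound 1 to compound 3 (0.49 log units; beyond the scatter). Going by these compounds, whether the change behaves the same on the core of compound 2 is untested, so the range is kept wide. The estimated solubility of compound 4 in this assay is 4500 nM, within 2000 nM to 10000 nM.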

Compound 4, solubility: 9660 nM
Beside the measured number, compound 4's estimate is 2.1-fold (0.33 log units) below it, and the stated range covers the measured number.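

Carried to the second core, the change from (2-methoxyethyl)amino to (3-methoxypropyl)amino gives, in this assay, a 1.3-fold lower number from compound 2 to compound 4 (0.12 log units; within the scatter), whereas on the first core it gave a 3.1-fold lower number from compound 1 to compound 3 (0.49 log units; beyond the scatter). The step that stands beyond the scatter on the core of compound 1 therefore does not stand beyond it on the core of compound 2, so the earlier step cannot be taken as a fixed increment that transfers between these two cores. With a single pair on each core and no repeat of either step, this does not show that the core governs the size of the step, nor that the change would stay within the scatter on the core of compound 2 in further pairs, and nothing available bears on the reason for the contrast.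

The compounds shown leave open how a longer methoxyalkyl chain, or a chain ending in a dimethylamino group or a carboxylic acid in place of the methoxy group, would read on either core. Also open, going by these compounds, is whether the same change on a further core would track the pair on the core of compound 1 or the pair on the core of compound 2.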